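The source may hold more compounds than are shown below. What is called first, only, known or untested is meant among the compounds shown, and "the series" means these compounds.

Compound 1 `CC(C)CCn1nc(C(=O)N[C@H]2COc3ccccc3N(C)C2=S)nc1Cc1ccccc1` and compound 2 `CN1C(=S)[C@@H](NC(=O)c2nc(Cc3ccccc3)n(CCCC(F)(F)F)n2)COc2ccccc21` share one core, differing only in the chain on the aromatic nitrogen. In a functional assay on HT-29 cells (Homo sapiens) for inhibition, read by luminescence and CellTiter-Glo, with a stated time of 24 h (a higher number here means that more compound is needed for the effect, a lower number that less compound is needed), compound 1 gives 3640 nM, and in this assay compound 2 gives 2380 nM. The change from compound 1 to compound 2 is 2,2,2-trifluoroethyl in place of isopropyl on a saturated chain carbon, two bonds along the chain from an aromatic nitrogen, and it gives a 1.5-fold lower number from compound 1 to compound 2 (0.18 log units; within the scatter). For the measured compounds named here, compound 2 thus has the lowest of the two numbers, though its only neighbour lies within the scatter. Compound 3 `CN1C(=S)[C@@H](NC(=O)c2nc(Cc3ccccc3)n(CC3COC3)n2)COc2ccccc21` differs from compound 2 as follows: oxetan-3-yl in place of 3,3,3-trifluoropropyl on a saturated chain carbon bound to an aromatic nitrogen. Going by the values given here, no measured step covers a ring entering at this place, and the only step seen on this chain was small. Compound 3 is therefore expected to give about 3000 nM in this assay, with a range of 1200 nM to 8000 nM, a step of a 1.3-fold higher number from compound 2 to compound 3 (0.10 log units; within the scatter) that is expected to stay within the scatter.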

Compound 3, half-maximal effective concentration: 2830 nM
Estimate against measurement, compound 3: 1.1-fold (0.03 log units) above; the range from low to high includes it.
By their numbers in this assay, from the lowest: compounds 2, 3 and 1 (each within the scatter of the next).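

For the compounds shown here, compound 3 puts a ring on this chain for the first time, and in this assay the oxetan-3-yl group, with its one hydrogen-bond acceptor, does not separate from either open-chain group: the data give a 1.2-fold higher number from compound 2 to compound 3 (0.08 log units; within the scatter) and a 1.3-fold lower number from compound 1 to compound 3 (0.11 log units; within the scatter). At this place, on a saturated chain carbon bound to an aromatic nitrogen, compounds 1, 2 and 3 therefore form one band within the scatter, whether the group is branched, fluorinated or a four-membered ring with an oxygen. No evidence is available to account for this flat result. From the compounds shown here alone, what remains open is whether a group of another kind here, such as an amine, a carboxylic acid or a much longer chain, would move the number beyond the scatter. The three compounds also say nothing about changes elsewhere on the shared core.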